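The source may report more compounds than this note shows. Statements on the series, on what has been measured and on what is new or still open speak of the compounds shown alone.

Measured so far:
compound 1 `C=C1C[C@]23C[C@@]1(O)CC[C@H]2c1ccc(OS(=O)(=O)c2ccc(C)cc2)c(C)c1[C@@H]3Cn1cc(-c2ccc(OC)cc2)nn1`: in a functional assay on HL-60 cells (Homo sapiens) for cytotoxicity, read by MTT assay, with a stated time of 4 days (on this read-out higher numbers stand for weaker inhibition and lower numbers for stronger inhibition), compound 1 gives > 20000 nM, which is a limit of the assay and not a number.
compound 2 `Cc1ccc(-c2cn(C[C@H]3c4c(ccc(OS(=O)(=O)c5ccc(C)cc5)c4C)[C@@H]4CC[C@@]5(C)C[C@]43CC5=O)nn2)cc1`: in this assay compound 2 gives > 20000 nM, likewise a limit of the assay.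

Compound 1 stands at the limit of this assay (the limit of > 20000 nM in this assay, at which 2 of the 2 values shown sit); no number is known for it, and the same holds for compound 2, so no ordering between the two can be drawn from what is shown. Within the data shown here, no step between measured compounds differing in a single place is available.

Compound 3 `C=C1C[C@]23C[C@@]1(O)CC[C@H]2c1ccc(OS(=O)(=O)c2ccc(C)cc2)c(C)c1[C@@H]3Cn1cc(-c2ccccc2)nn1` is to be measured in this assay. It differs from compound 1 by hydrogen in place of methoxy on an aromatic carbon — hydrogen in place of methoxy on an aromatic carbon, the same difference cut one bond further out reading as 4-methoxyphenyl to phenyl. Among the measured compounds shown here, with compound 1 sitting only at a limit, no measured step gives the size of such a change here. The step from compound 1 to compound 3 is expected at a number no higher from compound 1 to compound 3 (the limit leaves the size open), meaning nothing beyond the scatter. Compound 3 is therefore expected to give 20000 nM (range 8000 nM to 50000 nM), most likely reported again as a limit.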

Compound 3, half-maximal inhibitory concentration: > 20000 nM
Compound 3: no number, only a limit; the forecaster's own chance of this, stated with the estimate: 75%; the middle value lies on the limit itself.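

Compound 3 gives > 20000 nM in this assay, a limit and not a number. Among these compounds, compound 1 gives > 20000 nM, also a limit, so no step between the two can be read. The compounds shown leave open whether 4-methoxyphenyl to phenyl changes the read-out at all, since every value is a limit: the limit of > 20000 nM in this assay, at which 3 of the 3 values shown sit.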